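Removing the Methoxy from the Sulfonamide Core

The source may hold more compounds than are shown below. What is called first, only, known or untested is meant among the compounds shown, and "the series" means these compounds.

Compound 1 `COc1cccc(N2C(=O)COc3ccc(-c4cnc(Cl)c(NS(=O)(=O)c5ccc(F)cc5)c4)cc32)c1`: > 40000 nM
Compound 2 `COc1cccc(N2C(=O)COc3ccc(-c4cnc(OC)c(NS(=O)(=O)c5ccc(F)cc5)c4)cc32)c1`: > 40000 nM
Compound 3 `COc1cccc(N2C(=O)COc3ccc(-c4cccc(NS(=O)(=O)c5ccc(F)cc5)c4)cc32)c1`: > 40000 nM

In a functional assay on A-375 cells (Homo sapiens) for antiproliferative activity, read by MTT assay, with a stated time of 72 h (a higher number here means a weaker inhibitor, a lower number a stronger inhibitor), compound 1 gives > 40000 nM, which is a limit of the assay rather than a number. Compound 2 likewise gives a limit, > 40000 nM. Compound 3 also gives a limit, > 40000 nM. All three values sit at the limit of > 40000 nM in this assay, at which 3 of the 3 values shown sit, so compound 1 cannot be placed relative to the others on the numbers shown. Among the measured compounds shown here, the only single-point step among them, methoxy in place of chloro on an aromatic carbon, reads as a step that the two limits leave unreadable from compound 1 to compound 2 from compound 1 to compound 2.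

Compound 4 `O=C1COc2ccc(-c3cnc(Cl)c(NS(=O)(=O)c4ccc(F)cc4)c3)cc2N1c1ccccc1` differs from compound 1 by hydrogen in place of methoxy on an aromatic carbon. For the measured compounds named here, none of the measured steps touches this part of the shared core, and the one measured step is unreadable, so no step beyond the scatter can be foreseen in this assay in either direction. The reading is therefore expected to remain a limit. Compound 4 is expected to give about 40000 nM in this assay, within 15000 nM to 100000 nM. That expectation amounts to a step of a number no higher from compound 1 to compound 4 (the limit leaves the size open) from compound 1 to compound 4.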

Compound 4, half-maximal inhibitory concentration: 36900 nM
Estimate against measurement, compound 4: 1.1-fold (0.04 log units) above; the range from low to high includes it.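

With compound 4, this assay gives its first reading among the compounds shown that is a number rather than a limit: compound 4 gives 36900 nM. Compound 1 gives > 40000 nM, which is a limit of the assay and not a number. As far as these compounds go, the change from 3-methoxyphenyl to phenyl therefore reads as an at least 1.0-fold lower number from compound 1 to compound 4 (0.03 log units; that floor lies within the scatter), so a reading within the measurable range does not need the methoxy at this place, meta to a large group, while the true size of the change stays open.

The compounds shown leave open whether another group at this place on the same ring, such as an amine, a hydroxyl or a carboxylic acid, would give a clearly lower number than compound 4 does. The step from chloro to methoxy cannot be read, and the other compounds offer no number against which compound 4 could be set, since nearly all of the readings remain limits: the limit of > 40000 nM in this assay, at which 3 of the 4 values shown sit.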